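The compounds below may be only part of what the source reports. "The series", "measured", "known", "first", "only" and "open" are said of these compounds alone.

Series notes, toxicity read-out. The shared core carries a para-substituted phenyl; compound 1 `O=C(CN1CCCC1)Nc1ccc(-c2nc3cc(C(F)(F)F)ccc3[nH]2)cc1` bears the (((pyrrolidin-1-yl)methyl)carbonyl)amino group there and a trifluoromethyl on the core. In an ADME assay on MT4 cells (Homo sapiens) for cytotoxicity, read by MTT assay, with a stated time of 96 h (on this read-out higher numbers stand for lower toxicity in this test and lower numbers for higher toxicity in this test), compound 1 gives 18000 nM, the second highest of the three numbers measured. Compound 2 `O=[N+]([O-])c1ccc(-c2nc3cc(Cl)c(Cl)cc3[nH]2)cc1` gives 17000 nM, within the scatter of compound 1, though it differs from compound 1 in more than one place, so its two values are only set side by side. For the measured compounds named here, compound 3 `O=C(CN1CCCC1)Nc1ccc(-c2nc3ccccc3[nH]2)cc1` gives 40000 nM, and the one single-point step measured so far is a 2.2-fold higher number from compound 1 to compound 3 (0.35 log units; beyond the scatter), on the core rather than on the phenyl ring.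

Compound 4 `COc1ccc(-c2nc3cc(C(F)(F)F)ccc3[nH]2)cc1` is the next candidate. Change from compound 1: methoxy in place of (((pyrrolidin-1-yl)methyl)carbonyl)amino on an aromatic carbon. Going by the values given here, no measured step touches the group on the phenyl ring in isolation; compound 2, which carries a nitro at that position on a differently substituted core, gives a number close to that of compound 1. With nothing pointing either way, the expected step is a 1.1-fold lower number from compound 1 to compound 4 (0.05 log units; within the scatter), essentially none beyond the scatter. Compound 4 is therefore expected at about 16000 nM, estimated range 5000 nM to 50000 nM.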

Compound 4, half-maximal cytotoxic concentration: 2000 nM
For compound 4 the middle estimate is 8.0-fold (0.90 log units) above the measured one, outside the stated range (below it).
By their numbers in this assay, from the lowest: compound 4; then compounds 2 and 1 (each within the scatter of the next); then compound 3.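

For the compounds shown here, on the phenyl ring, a position that had no isolated step before, the group clearly matters in this assay: a 9.0-fold lower number from compound 1 to compound 4 (0.95 log units; beyond the scatter), with the lower number standing for higher toxicity in this test, and this step is larger than the one on the core, a 2.2-fold higher number from compound 1 to compound 3 (0.35 log units; beyond the scatter), seen earlier. The change removes the five-membered non-aromatic ring, the carbonyl and the hydrogen-bond donor together, so this single step cannot assign the shift to any one of these parts. Nothing available explains the shift.

The compounds shown leave open whether a plain amine or a shorter acetylamino group at this position would stay closer to compound 1 or to compound 4. Also open, on these data alone, is whether hydrogen in place of trifluoromethyl on the core would raise the number when methoxy is present, as it does alongside the larger group.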